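A few compounds are considered here, and "the series" means these few. Any claim that something is new, unique, unknown or untested is made for them only; others in the source may bear on it.

Compound 3 `COc1ccc(CCCc2nc(N)c3nn(-c4ccccc4)cc3n2)cc1` gives 1% in an assay on CHO cells for displacement of a labelled ligand from adenosine receptor A3 (Homo sapiens), read by scintillation counting, tested at 1 uM (a higher number here means more inhibition at the concentration tested (going by the name of the read-out), a lower number less inhibition), the lowest of the three numbers in hand. Compound 1 `Nc1nc(CCc2ccccc2)nc2cn(-c3ccccc3)nc12` gives 17% and compound 2 `Nc1nc(CCc2ccc(O)cc2)nc2cn(-c3ccccc3)nc12` gives 37%; the steps down to compound 3 are a number 16 percentage points lower from compound 1 to compound 3 (beyond the scatter) and a number 36 percentage points lower from compound 2 to compound 3 (beyond the scatter), while a number 20 percentage points higher from compound 1 to compound 2 (beyond the scatter). Compound 4 `C=CCOc1ccc(CCCc2nc(N)c3nn(-c4ccccc4)cc3n2)cc1` differs from compound 3 by vinyl in place of hydrogen on a saturated chain carbon bound to an oxygen on an aromatic ring. Among the compounds with values here, no measured step touches this part of the structure; the changes seen so far alter the group on the saturated chain carbon, and both lead to the low number of compound 3. Nothing in hand points to a movement beyond the scatter, so the expected step is a number 2 percentage points higher from compound 3 to compound 4 (within the scatter). Compound 4 is estimated at 3%, between -6% and 14%.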

Compound 4, a percentage reported as inhibition, at one concentration (the size of the read-out at that concentration, not a potency): 3%
For compound 4 middle estimate and measured number coincide at the digits printed, and the stated range covers the measured number.
By their numbers in this assay, from the lowest: compounds 3 and 4 (each within the scatter of the next); then compound 1; then compound 2.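

Methoxy to allyloxy is the first change read at the far end of this ether, and in this assay it gives no separation between the two compounds (a number 2 percentage points higher from compound 3 to compound 4 (within the scatter)). Adding vinyl on the saturated chain carbon bound to the oxygen therefore gives no reading beyond the scatter, though both numbers are so low that little can be resolved here. No measured evidence bears on this result.

Still open, going by these compounds, is how an amine or a carboxylic acid at the end of this ether would read. Whether a longer chain there would separate from compound 3 is also unresolved.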